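The source may report more compounds than this note shows. Statements on the series, on what has been measured and on what is new or still open speak of the compounds shown alone.

Measured compounds:
- compound 1 `O=C(Nc1ncc(Cc2ccc(Br)cc2)s1)c1ccc2ccccc2c1`: in an ADME assay on HepG2 2.2.15 cells (Homo sapiens) for cytotoxicity (on this read-out lower numbers stand for higher toxicity in this test and higher numbers for lower toxicity in this test), compound 1 gives > 50000 nM, which is a limit of the test rather than a number.
- compound 2 `O=C(Nc1ncc(C(OCc2ccc(F)cc2Br)c2ccccc2)s1)c1cccs1`: in this assay compound 2 gives "not toxic" (no number reported), with no number reported.
- compound 3 `Clc1ccc(C(Oc2ccc3cc(Br)ccc3c2)c2cnc(NCC3CCCCC3)s2)cc1`: in this assay compound 3 gives "not toxic" (no number reported), again without a number.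

Compound 3 thus stands without a single number in this assay; of the other two entries, one is a limit and one is likewise only a statement without a number, so no order among the three can be drawn and all three sit at the non-toxic end of what the test can report.

Compound 4 `Clc1ccc(C(Oc2ccc3cc(Br)ccc3c2)c2cnc(NCC3CCOCC3)s2)cc1` differs from compound 3 in one place: oxan-4-yl in place of cyclohexyl on a saturated chain carbon bound to a nitrogen on an aromatic ring. For the measured compounds named here, no step between measured compounds is available to size this change. In this assay no shift beyond the usual scatter is expected on going from compound 3 to compound 4; the likely outcome is a reading at or past the upper boundary of the test, in keeping with the limit of > 50000 nM in this assay, at which 1 of the 3 values shown sits. Compound 4 is therefore expected to give about 50000 nM, within 20000 nM to 100000 nM, and most probably to be reported only as a limit.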

Compound 4, half-maximal cytotoxic concentration: "not toxic" (no number reported)
Compound 4: no number reported, and the estimate cannot be compared.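

No step can be read from compound 3 to compound 4 in this assay, since compound 3 gives "not toxic" (no number reported) and compound 4 gives "not toxic" (no number reported). The compounds shown leave open whether oxan-4-yl in place of cyclohexyl changes the half-maximal cytotoxic concentration in this assay at all.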